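Triazole-linked terpenoid phenols: aryl methyl against chloro

This account rests on a few compounds, and the source may have more. Where it says the series, first, only, none or still open, it means among the compounds named here.

Compound 1 `Cc1c(O)ccc2c1[C@H](Cn1cc(-c3ccc(Cl)cc3)nn1)[C@@]13CC(=O)[C@@](C)(CC[C@@H]21)C3` and compound 2 `Cc1ccc(-c2cn(C[C@H]3c4c(ccc(O)c4C)[C@@H]4CC[C@@]5(C)C[C@]43CC5=O)nn2)cc1` share one core and differ only in the group on the distal aromatic ring. In a functional assay on A549 cells (Homo sapiens) for cytotoxicity, read by MTT assay, with a stated time of 4 days (a higher number here means a weaker inhibitor, a lower number a stronger inhibitor), compound 2 gives > 20000 nM, which is a limit of the assay and not a number. In this assay compound 1 gives > 20000 nM, likewise a limit. The change chloro in place of methyl on an aromatic carbon therefore yields a step that the two limits leave unreadable from compound 2 to compound 1. Compound 3 `C=C1C[C@]23C[C@@]1(O)CC[C@H]2c1cc(Br)c(O)c(C)c1[C@@H]3Cn1cc(-c2ccc(C)cc2)nn1` rests on another core; the difference between the core of compound 3 and that of compound 2 is not broken down here. In this assay compound 3 gives > 20000 nM, again only a limit. Going by the values given here, all three measured compounds thus sit on (the limit of > 20000 nM in this assay, at which 3 of the 3 values shown sit), and no step among them can be read.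

Compound 4 `C=C1C[C@]23C[C@@]1(O)CC[C@H]2c1cc(Br)c(O)c(C)c1[C@@H]3Cn1cc(-c2ccc(Cl)cc2)nn1` is the untested member, related to compound 3 by chloro in place of methyl on an aromatic carbon. Its place reads word for word as in the pair from compound 2 to compound 1, so the two changes are the same kind of change at the same kind of position. Because the pair from compound 2 to compound 1 produced a step that the two limits leave unreadable from compound 2 to compound 1, nothing shows this change moving a compound off the limit. The expectation for compound 4 rests on compound 3 returning only a limit in this assay. Compound 4 is therefore expected to give about 35000 nM, within 20000 nM to 150000 nM, most likely reported as a limit. The expected step from compound 3 to compound 4 is a step that the limit leaves unreadable from compound 3 to compound 4, set beside the unreadable earlier one.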

Compound 4, half-maximal inhibitory concentration: 10500 nM
For compound 4 the middle estimate is 3.3-fold (0.52 log units) above the measured one; measured number below the stated range.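

On the core of compound 3, chloro in place of methyl gives in this assay an at least 1.9-fold lower number from compound 3 to compound 4 (0.27 log units; that floor lies within the scatter), so the step points to a lower number, but its floor does not clear the scatter. Going by these compounds alone, compound 4 gives 10500 nM, the only value that is a number. Every other compound shown remains a limit: the limit of > 20000 nM in this assay, at which 3 of the 4 values shown sit. On the core of compound 2 the same change leads to compound 1 at > 20000 nM, a limit of the assay; the steps that rest on limits alone cannot be read, so the drop seen on the core of compound 3 cannot be said to carry over to the core of compound 2, and these compounds show no transfer of the change between cores.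

From the compounds shown here alone, the full size of the step on the core of compound 3 stays open, as does whether any other core would respond to 4-methylphenyl to 4-chlorophenyl in the same way. Also open, going by these compounds, is what other groups would do at this place, on an aromatic carbon para to a large group, for example an amine, a carboxylic acid or a longer chain.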